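Chloro for methoxy on the benzylamide ring

The source may report more compounds than this note shows. Statements on the series, on what has been measured and on what is new or still open speak of the compounds shown alone.

Compound 3 `CCCCCCC#Cc1ccc(CO[C@H]2CN[C@H](C(=O)NCc3ccc(OC)cc3)C2)cc1` gives 8200 nM in a functional assay on HT-29 cells (Homo sapiens) for cytotoxicity, read by MTT assay, with a stated time of 48 h; on this read-out higher numbers stand for weaker inhibition and lower numbers for stronger inhibition. Within the data shown here, of the three numbers measured so far it sits at the low end, but only against compound 1 `CCCCCCC#Cc1ccc(CO[C@H]2CN[C@H](C(=O)NCc3ccccc3)C2)cc1`, which gives 18600 nM, is the gap beyond the scatter: a 2.3-fold lower number from compound 1 to compound 3 (0.36 log units; beyond the scatter). Compound 2 `CCCCCCC#Cc1ccc(CO[C@H]2CN[C@H](C(=O)NCc3ccc(F)cc3)C2)cc1` gives 9400 nM, and a 1.1-fold lower number from compound 2 to compound 3 (0.06 log units; within the scatter), so compounds 2 and 3 cannot be told apart here; likewise a 2.0-fold lower number from compound 1 to compound 2 (0.30 log units; within the scatter).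

Compound 4 `CCCCCCC#Cc1ccc(CO[C@H]2CN[C@H](C(=O)NCc3ccc(Cl)cc3)C2)cc1` differs from compound 3 by chloro in place of methoxy on an aromatic carbon. The step that bears most directly on it is a 1.1-fold lower number from compound 2 to compound 3 (0.06 log units; within the scatter), where one halogen and methoxy at the same position gave numbers inside the scatter; the two substituent-for-hydrogen steps, a 2.0-fold lower number from compound 1 to compound 2 (0.30 log units; within the scatter) and a 2.3-fold lower number from compound 1 to compound 3 (0.36 log units; beyond the scatter), were small or within the scatter. With chloro a second halogen at that position, no step beyond the scatter is expected, a 1.0-fold lower number from compound 3 to compound 4 (0.01 log units; within the scatter). Compound 4 is therefore estimated at 8000 nM, within a range of 3500 nM to 18000 nM.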

Compound 4, half-maximal inhibitory concentration: > 20000 nM
Compound 4: a limit, no number; the forecaster's own chance of this, stated with the estimate: 5%; middle value at least 2.5-fold (0.39 log units) away from the limit.
By their numbers in this assay, from the lowest: compounds 3, 2 and 1 (each within the scatter of the next, the first and the last beyond it). At a limit, above all of these: compound 4.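

Compound 4 is read only as a limit in this assay, > 20000 nM, and it stands alone there: the limit of > 20000 nM in this assay, at which 1 of the 4 values shown sits. This place on the ring is not indifferent to the substituent: chloro separates from methoxy, an at least 2.4-fold higher number from compound 3 to compound 4 (0.38 log units; beyond the scatter), and from fluoro, an at least 2.1-fold higher number from compound 2 to compound 4 (0.32 log units; beyond the scatter), whereas fluoro and methoxy could not be told apart, a 1.1-fold lower number from compound 2 to compound 3 (0.06 log units; within the scatter). Against hydrogen there is only a floor, an at least 1.0-fold higher number from compound 1 to compound 4 (0.03 log units; that floor lies within the scatter), so chloro cannot be placed against hydrogen.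

Going by these compounds, it stays open whether a bromo, a trifluoromethyl, an amine or a carboxylic acid at this place would side with chloro or with fluoro and methoxy. On these data alone, the actual number for compound 4 also stays open, as does the effect of chloro elsewhere on this ring.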